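Bromo for ethyl at the meta position of compound 1

The source may hold more compounds than are shown below. What is called first, only, known or untested is meant among the compounds shown, and "the series" means these compounds.

Compound 1 `CCc1cccc(N2CCCC(=O)N2)c1` holds the lowest number of the three measured: in an assay on isolated protein for inhibition of Polyunsaturated fatty acid 5-lipoxygenase (Homo sapiens) (on this read-out lower numbers stand for stronger inhibition and higher numbers for weaker inhibition), compound 1 gives 3000 nM. The two chloro analogues sit far weaker, both beyond the scatter: compound 2 `O=C1CCCN(c2ccccc2Cl)N1` gives 99000 nM and compound 3 `O=C1CCCN(c2ccc(Cl)cc2)N1` gives 79000 nM in this assay. Compound 4 `O=C1CCCN(c2cccc(Br)c2)N1` carries bromo in place of ethyl on an aromatic carbon, meta to a group of 7 heavy atoms. For the measured compounds named here, no matched step between measured compounds tells how this swap acts. The chloro analogues are weak, but they place the halogen elsewhere, so they give no direct guide. A moderate loss is expected, from compound 1 to compound 4 of a 3.0-fold higher number from compound 1 to compound 4 (0.48 log units; beyond the scatter). Compound 4 is therefore expected near 9000 nM, within 2000 nM to 40000 nM.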

Compound 4, half-maximal inhibitory concentration: 1800 nM
Compound 4: middle estimate off by 5.0-fold (0.70 log units), on the high side; measured number outside the range, below it.
By their numbers in this assay, from the lowest: compounds 4 and 1 (each within the scatter of the next); then compounds 3 and 2 (each within the scatter of the next).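

In this assay, bromo in place of ethyl on this aromatic carbon gives a 1.7-fold lower number from compound 1 to compound 4 (0.22 log units; within the scatter), so the two groups cannot be told apart here. Ethyl is thus not required at this carbon: a single bromine atom serves as well as the two-carbon chain on the shared core. As far as these compounds go, whether an amine, a carboxylic acid or a longer chain such as butyl at this same carbon would hold the number at this level stays open. No measurement at hand accounts for the two groups reading alike.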